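The Same Swap on an Aromatic Nitrogen, Tried Twice

The source may hold more compounds than are shown below. What is called first, only, known or untested is meant among the compounds shown, and "the series" means these compounds.

Compound 1 `COC(=O)Cn1cc(CO[C@H]2CC(=O)[C@@H]3OC[C@H]2O3)nn1` and compound 2 `O=C1C[C@H](OCc2cn(C(=O)c3ccccc3)nn2)[C@H]2CO[C@@H]1O2` share one core and differ in a single place: benzoyl in place of (methoxycarbonyl)methyl on an aromatic nitrogen. In a functional assay on MDA-MB-231 cells (Homo sapiens) for cytotoxicity, read by MTT assay, with a stated time of 48 h (a higher number here means a weaker inhibitor, a lower number a stronger inhibitor), compound 1 gives 21300 nM, and compound 2 gives 25900 nM; the step of a 1.2-fold higher number from compound 1 to compound 2 (0.08 log units; within the scatter). Compound 3 `COC(=O)Cn1cc(CN(C(C)=O)[C@H]2CC(=O)[C@@H]3OC[C@H]2O3)nn1` is built on a different core, and the difference between the two cores is not broken down here. In this assay compound 3 gives only a limit, > 50000 nM. Compound 4 `CC(=O)N(Cc1cn(C(=O)c2ccccc2)nn1)[C@H]1CC(=O)[C@@H]2OC[C@H]1O2` has not been measured; it differs from compound 3 by the same change: benzoyl in place of (methoxycarbonyl)methyl on an aromatic nitrogen. Since this change left the value unmoved from compound 1 to compound 2 a 1.2-fold higher number from compound 1 to compound 2 (0.08 log units; within the scatter), a step of similar size is expected here, a step that the limit leaves unreadable from compound 3 to compound 4. Compound 4 is therefore estimated at 60000 nM, between 30000 nM and 150000 nM, and another limit is likely.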

Compound 4, half-maximal inhibitory concentration: > 50000 nM
Compound 4: no number, only a limit; the forecaster's own chance of this, stated with the estimate: 75%; the middle value does not contradict the limit.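

Compound 3 and compound 4 both give only a limit, not a number, so no step between them can be read: the limit of > 50000 nM in this assay, at which 2 of the 4 values shown sit.

The compounds shown leave open whether benzoyl in place of (methoxycarbonyl)methyl on an aromatic nitrogen changes the true value on the core of compound 3.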